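The source may hold more compounds than are shown below. What is called first, only, known or untested is meant among the compounds shown, and "the series" means these compounds.

For the measured compounds named here, compound 1 `Cc1[nH]ncc1-c1cncc(-c2ccc(C(N)=O)c(OC(C)C)c2)c1` stands at the low end of the three numbers measured so far in an assay on cells for inhibition of MAP kinase-interacting serine/threonine-protein kinase 1 (Homo sapiens), read by mobility shift assay, with stated times of 10 min and 60 min, in the presence of a further agent that is not named here (a lower number here means a stronger inhibitor, a higher number a weaker inhibitor), where compound 1 gives 54 nM. The nearest of the others is compound 2 `COc1cc(C(N)=O)ccc1-c1cccnc1`, which in this assay gives 29300 nM, a gap well beyond the scatter. Compound 3 `CNC(=O)c1ccc(-c2cccnc2)cc1` lies furthest away and in this assay gives 292000 nM. Both weaker compounds lack the five-membered aromatic ring that compound 1 carries.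

Compound 4 `CC(C)Oc1cc(-c2cccnc2)ccc1C(N)=O` has not been measured yet. It differs from compound 1 in one place: hydrogen in place of 5-methyl-1H-pyrazol-4-yl on an aromatic carbon. Compound 4 therefore keeps the amide and the isopropoxy group of compound 1 but resembles compound 2 in having a bare carbon at that position.

No step between measured compounds is shown, so the expectation rests on the values alone. Because compound 2 gives 29300 nM and compound 3 gives 292000 nM, a large step toward a higher number, far beyond the scatter, is expected for compound 4. The step from compound 1 to compound 4 is estimated as a 280-fold higher number from compound 1 to compound 4 (2.44 log units; beyond the scatter). Compound 4 is expected to give about 15000 nM, with a likely range from 3000 nM to 60000 nM.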

Compound 4, half-maximal inhibitory concentration in the MAP kinase-interacting serine/threonine-protein kinase 1 assay: 880 nM
The estimate for compound 4 lay 17-fold (1.23 log units) above the measured number; the whole stated range lies above it.
By their numbers in the MAP kinase-interacting serine/threonine-protein kinase 1 assay, from the lowest: compound 1; then compound 4; then compound 2; then compound 3.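

The 5-methyl-1H-pyrazol-4-yl group at this carbon accounts for a real share of the inhibition, since in the MAP kinase-interacting serine/threonine-protein kinase 1 assay its replacement by hydrogen gives a 16-fold higher number from compound 1 to compound 4 (1.21 log units; beyond the scatter). That loss is only part of the story: compound 4 still gives 880 nM in the same assay, so much of the inhibition remains without the five-membered ring. In a physicochemical assay for solubility, measured as thermodynamic solubility, at pH 7.4 (on this read-out higher numbers stand for higher solubility and lower numbers for lower solubility), the same change moves the number the other way, with compound 1 at 11 ug/mL and compound 4 at 45 ug/mL, the smaller compound the more soluble of the pair: the measured solubility of compound 1, 11 ug/mL, and of compound 4, 45 ug/mL, a 4.1-fold higher number (0.61 log units; beyond the scatter).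

As far as these compounds go, what remains open is which part of the group carries the gain, the ring itself, its ring hydrogen or its methyl. Nor do the compounds shown tell whether a phenyl ring or a small amine at this carbon would keep the inhibition while giving up less solubility.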